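Compound 2 and a return to the methoxy aryl

The source may report more compounds than this note shows. Statements on the series, on what has been measured and on what is new or still open speak of the compounds shown alone.

Measured in a functional assay on HT-1080 cells (Homo sapiens) for antiproliferative activity, read by MTT assay, with a stated time of 72 h; on this read-out higher numbers stand for weaker inhibition and lower numbers for stronger inhibition:
compound 1 `CCOC(=O)c1cc(-c2cc(OC)c(OC)c(OC)c2)c(-c2ccc(OC)cc2)s1`: 8370 nM
compound 2 `CCOC(=O)c1cc(-c2cc(OC)c(OC)c(OC)c2)c(-c2cccc(Br)c2)s1`: > 100000 nM

Compound 2 sits at the limit of > 100000 nM in this assay, at which 1 of the 2 values shown sits, so it has a limit and not a number. Compound 3 `CCOC(=O)c1cc(-c2cc(OC)c(OC)c(OC)c2)c(-c2ccc(OC)c([N+](=O)[O-])c2)s1`, not yet measured, carries 4-methoxy-3-nitrophenyl in place of 3-bromophenyl on an aromatic carbon next to the ring sulfur of the shared core (4-methoxy-3-nitrophenyl in place of 3-bromophenyl on an aromatic carbon). Within the data shown here, only one measured step bears on this change: an at least 11-fold higher number from compound 1 to compound 2 (1.07 log units; beyond the scatter). That step was large and beyond the scatter. Among the measured compounds shown here, compound 3 shares the 4-methoxy group with the 4-methoxyphenyl of compound 1 at 8370 nM, but its nitro group has no measured precedent. A move towards a lower number is therefore expected in this assay, though with wide uncertainty. The estimated change is an at least 8.3-fold lower number from compound 2 to compound 3 (0.92 log units; beyond the scatter). For compound 3 the expected value is 12000 nM, with an estimated range from 2500 nM to 60000 nM.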

Compound 3, half-maximal inhibitory concentration: 12700 nM
The estimate for compound 3 lay 1.1-fold (0.02 log units) below the measured number; low and high end bracket the measured number.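

In this assay, 4-methoxy-3-nitrophenyl in place of 3-bromophenyl on this aromatic carbon next to the ring sulfur gives an at least 7.8-fold lower number from compound 2 to compound 3 (0.89 log units; beyond the scatter). Compound 2 is a limit and not a number, so the size of that step is known only as a bound: the limit of > 100000 nM in this assay, at which 1 of the 3 values shown sits. Nitro in place of hydrogen on the aryl group of compound 1 gives a 1.5-fold higher number from compound 1 to compound 3 (0.18 log units; within the scatter), so compound 1 and compound 3 cannot be told apart here, and this position takes the added nitro group with a measurable result.

It remains open whether the loss in compound 2 goes with the bromine itself or with the absence of the 4-methoxy group, since no compound shown carries both groups. Also open, on these data alone, is how an amine in place of the nitro group would read in this assay.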